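Swapping Trifluoromethyl for Trifluoromethoxy on an Aryl Urea

The source may hold more compounds than are shown below. What is called first, only, known or untested is meant among the compounds shown, and "the series" means these compounds.

Measured so far in a physicochemical assay for solubility, read by mass spectrometry, in phosphate buffer, with a stated time of 24 h, at pH 7.4; a lower number here means a less soluble compound, a higher number a more soluble compound:
compound 1 `O=C(Nc1ccc(OC(F)(F)F)cc1)NC1CCN(C(=O)c2ccoc2)CC1`: 7.6 ug/mL
compound 2 `CC(C)C(=O)N1CCC(NC(=O)Nc2ccc(C(F)(F)F)c(F)c2)CC1`: 5.9 ug/mL
compound 3 `O=C(Nc1ccc(OC(F)(F)F)cc1)NC1CCN(C(=O)C2CCCOC2)CC1`: 94 ug/mL

Compound 2 has the lowest of these three numbers, yet its gap to compound 1 lies within the scatter, so the two cannot be told apart; compound 3 stands clearly higher. Compound 4 `CC(C)C(=O)N1CCC(NC(=O)Nc2ccc(OC(F)(F)F)c(F)c2)CC1` differs from compound 2 in one place: trifluoromethoxy in place of trifluoromethyl on an aromatic carbon. Among the measured compounds shown here, no measured step touches this position. For the measured compounds named here, the only step known, a 12-fold higher number from compound 1 to compound 3 (1.09 log units; beyond the scatter), concerns the carbonyl substituent at the far end of the shared core and says nothing about the aromatic ring. Compound 1 already carries trifluoromethoxy and sits within the scatter of compound 2. No step beyond the scatter is therefore expected in this assay. For compound 4 the estimate is 7 ug/mL, with a range of 3 ug/mL to 18 ug/mL, which means an expected step of a 1.2-fold higher number from compound 2 to compound 4 (0.07 log units; within the scatter).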

Compound 4, solubility: 5.3 ug/mL
Estimate against measurement, compound 4: 1.3-fold (0.12 log units) above; measured number inside the range.
By their numbers in this assay, from the lowest: compounds 4, 2 and 1 (each within the scatter of the next); then compound 3.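

In this assay, this position on the aromatic ring now has its first direct comparison, which gives a 1.1-fold lower number from compound 2 to compound 4 (0.05 log units; within the scatter). Trifluoromethoxy and trifluoromethyl therefore cannot be told apart at this place, ortho to a fluoro group, with the isopropyl carbonyl end of compound 2 held fixed. No supporting data bear on this result.

Going by these compounds, what an amine or a carboxylic acid would give on this aromatic carbon remains open. So does whether the same swap reads alike with the oxan-3-yl carbonyl end of compound 3.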